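The source may hold more compounds than are shown below. What is called first, only, known or untested is meant among the compounds shown, and "the series" means these compounds.

In a functional assay on MCF7 cells (Homo sapiens) for antiproliferative activity, read by MTT assay, with a stated time of 72 h (on this read-out lower numbers stand for stronger inhibition and higher numbers for weaker inhibition), compound 1, with the structure `COc1ncc(-c2ccc3c(c2)N(c2ccc(C)cc2)C(=O)CO3)cc1NS(=O)(=O)c1ccc(F)cc1`, gives 15400 nM. Among the measured compounds shown here, this is the only actual number among the three compounds measured so far; the other two values are limits of the assay, (the limit of > 40000 nM in this assay, at which 2 of the 3 values shown sit). Compound 2 (`O=C1COc2ccc(-c3cccc(NS(=O)(=O)c4ccc(F)cc4)c3)cc2N1c1ccccc1`) reaches only a limit, > 40000 nM. Compound 3 (`COc1cccc(N2C(=O)COc3ccc(-c4ccc(O)cc4)cc32)c1`) likewise reaches only a limit, > 40000 nM. Compound 4 (`COc1ncc(-c2ccc3c(c2)N(c2ccc(Cl)cc2)C(=O)CO3)cc1NS(=O)(=O)c1ccc(F)cc1`) has not yet been measured in this assay. It differs from compound 1 in one place: chloro in place of methyl on an aromatic carbon. For the measured compounds named here, no step between two measured compounds is available to gauge what this change does to the read-out. For compound 4 the expected step is a 1.3-fold lower number from compound 1 to compound 4 (0.11 log units; within the scatter), within the usual scatter. Compound 4 is therefore expected to give 12000 nM, between 5000 nM and 30000 nM.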

Compound 4, half-maximal inhibitory concentration: 27600 nM
Compound 4: the middle estimate sits 2.3-fold (0.36 log units) below what was measured; measured number inside the range.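

Among the compounds shown here, exchanging methyl for chloro, which turns 4-methylphenyl into 4-chlorophenyl, gives a 1.8-fold higher number from compound 1 to compound 4 (0.25 log units; within the scatter) in this assay and is the first step that can be read at this position. On this evidence, the two groups cannot be told apart here. Compound 4, like compound 1, gives a real number and not a limit, while the remaining values are limits: the limit of > 40000 nM in this assay, at which 2 of the 4 values shown sit.

Going by these compounds, whether another group in this place, such as an amine, a carboxylic acid or a longer chain, would shift the number beyond the scatter stays open.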